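Pyridinyl for fluorophenyl on the aryl-bearing ring nitrogen

A few compounds are considered here, and "the series" means these few. Any claim that something is new, unique, unknown or untested is made for them only; others in the source may bear on it.

Two compounds of the series carry numbers. Compound 1 `O=C([C@@H]1C[C@H](N2CCN(c3nccn3-c3ccccc3)CC2)CN1)N1CCSC1` gives 59.3% in a functional assay on the whole organism (plasma, strain Wistar) for inhibition, with Rattus norvegicus as the target, read by fluorescence, with a stated time of 0.5 h, at a dose of 3 umol/kg by the oral route; a higher number here means more inhibition at the dose given (going by the name of the read-out), a lower number less inhibition. Compound 2 `Cc1cc(N2CCN([C@@H]3CN[C@H](C(=O)N4CCSC4)C3)CC2)n(-c2cccc(F)c2)n1` gives 96.1% in this assay, which is the higher of the two numbers; the gap to compound 1 is beyond the scatter, so compound 2 stands clearly ahead within this pair. Compound 3 `Cc1cc(N2CCN([C@@H]3CN[C@H](C(=O)N4CCSC4)C3)CC2)n(-c2cccnc2)n1` is not yet measured. It differs from compound 2 by pyridin-3-yl in place of 3-fluorophenyl on an aromatic nitrogen. Going by the values given here, no measured pair shows this change, so nothing tells how large a step it brings. As compound 2 sits close to the upper end of what a percentage of inhibition can show, the room upward is small; the expected step is a number 11.1 percentage points lower from compound 2 to compound 3 (beyond the scatter), at most a modest loss and possibly none beyond the scatter. Compound 3 is therefore estimated at 85% in this assay, with a likely range from 60% to 98%.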

Compound 3, a percentage reported as inhibition, in the whole organism at one dose (the size of the read-out at that dose, not a potency): 66.9%
Estimate against measurement, compound 3: 18.1 percentage points above; the measured number falls inside the stated range.
By their numbers in this assay, from the lowest: compounds 1 and 3 (each within the scatter of the next); then compound 2.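

In this assay, the group on the aromatic nitrogen now has its first readable step: pyridin-3-yl in place of 3-fluorophenyl gives a number 29.2 percentage points lower from compound 2 to compound 3 (beyond the scatter). This place is therefore not indifferent to exchanging one six-membered aromatic ring for another, and the high reading of compound 2 does not carry over to this change, in which a ring with one hetero atom and one hydrogen-bond acceptor enters and the fluorine leaves. Nothing at hand accounts for the size of this step.

Going by these compounds alone, the single step cannot separate the effect of losing the fluorine from that of gaining the ring nitrogen. Also open, as far as these compounds go, is how a methoxy group or an amine on the aryl ring would read here, and whether the step holds at other doses or times.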